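The source may report more compounds than this note shows. Statements on the series, on what has been measured and on what is new or still open speak of the compounds shown alone.

Compound 1, `Nc1ncnc2c1ccn2COC(CO)CO`, and compound 2, `OCC(CO)OCn1ccc2c(NO)ncnc21`, differ only by a hydroxy group on a nitrogen on an aromatic ring. In an ADME assay on HFF cells (Homo sapiens) for cytotoxicity (on this read-out lower numbers stand for stronger inhibition and higher numbers for weaker inhibition), compound 1 gives > 100000 nM, which is a limit of the assay. In this assay compound 2 gives > 100000 nM, likewise a limit. The step that the two limits leave unreadable from compound 1 to compound 2 stays unreadable because both values sit at the limit of > 100000 nM in this assay, at which 2 of the 2 values shown sit. Compound 3, `OCC(CO)OCn1ccc2cncnc21`, carries hydrogen in place of hydroxyamino on an aromatic carbon. Among the compounds with values here, no measured step covers this change, and compound 2 stands at the limit, so no shift beyond the scatter is expected. The estimated step is a number no higher from compound 2 to compound 3 (the limit leaves the size open). Compound 3 is expected to give 100000 nM, between 30000 nM and 300000 nM.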

Compound 3, half-maximal inhibitory concentration: > 100000 nM
Compound 3: only a limit was reported; the forecaster's own chance of this, stated with the estimate: 85%; the middle value sits exactly at the limit.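

No new step can be read between compound 3 and compound 2 or compound 1 in this assay, because each value is a limit: the limit of > 100000 nM in this assay, at which 3 of the 3 values shown sit. The compounds shown leave open how any of these changes affects cytotoxicity in these cells.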